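The source may report more compounds than this note shows. Statements on the series, on what has been measured and on what is new or still open speak of the compounds shown alone.

In a functional assay on A549 cells (Homo sapiens) for antiproliferative activity, read by MTT assay, with a stated time of 48 h (on this read-out higher numbers stand for weaker inhibition and lower numbers for stronger inhibition), compound 1 `O=C(/C=C/c1cc(Br)cc(Br)c1Oc1c([N+](=O)[O-])cc(C(F)(F)F)cc1[N+](=O)[O-])c1ccc(Cl)cc1` gives 19.4 ug/mL, compound 2 `O=C(/C=C/c1cccc(Br)c1Oc1c([N+](=O)[O-])cc(C(F)(F)F)cc1[N+](=O)[O-])c1ccc(Cl)cc1` gives 16.5 ug/mL, and compound 3 `O=C(/C=C/c1cccc(Cl)c1Oc1c([N+](=O)[O-])cc(C(F)(F)F)cc1[N+](=O)[O-])c1ccc(Cl)cc1` gives 11.7 ug/mL. The step of a 1.2-fold lower number from compound 1 to compound 2 (0.07 log units; within the scatter) and the step of a 1.4-fold higher number from compound 3 to compound 2 (0.15 log units; within the scatter) both stay within the scatter of repeated measurements. The change from compound 3 to compound 2 is bromo in place of chloro on an aromatic carbon. Compound 4 `O=C(/C=C/c1cc(Br)cc(Br)c1Oc1c([N+](=O)[O-])cc(C(F)(F)F)cc1[N+](=O)[O-])c1ccc(Br)cc1` has not been measured; relative to compound 1 it carries the same kind of change, (bromo in place of chloro on an aromatic carbon), though here the place is para to a large group rather than ortho to a large group and meta to a 2-((4-chlorophenyl)carbonyl)ethenyl group. The difference between the cores of compound 1 and compound 3 is not broken down here. Because the earlier step of a 1.4-fold higher number from compound 3 to compound 2 (0.15 log units; within the scatter) stayed within the scatter, compound 4 is expected to show a step of a 1.0-fold higher number from compound 1 to compound 4 (0.01 log units; within the scatter). Compound 4 is therefore estimated at 20 ug/mL, likely between 11 ug/mL and 36 ug/mL.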

Compound 4, half-maximal inhibitory concentration: 16.8 ug/mL
The estimate for compound 4 lay 1.2-fold (0.08 log units) above the measured number, within the range that was stated.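

In this assay, putting bromo in place of chloro on the 4-chlorophenyl group gives a step within the scatter, a 1.2-fold lower number from compound 1 to compound 4 (0.06 log units; within the scatter). Set beside the same exchange on another core, the two steps do not differ beyond the scatter: the same change on two cores in this assay, a 1.4-fold higher number (0.15 log units; within the scatter) from compound 3 to compound 2 and a 1.2-fold lower number (0.06 log units; within the scatter) from compound 1 to compound 4, 1.6-fold (0.21 log units) apart, within the scatter of two such steps This shows no sign that the outcome of the exchange depends on the core, but it does not show that the two cores respond alike, as the exchange also sits at a different place in each pair and only two pairs are available.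

The compounds shown leave open what an amine or a methoxy group would give in place of the bromo of compound 4. Also open, from the compounds shown here alone, is what a nitrile or a carboxylic acid would give in place of the trifluoromethyl group.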